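A few compounds are considered here, and "the series" means these few. Any claim that something is new, unique, unknown or untested is made for them only; others in the source may bear on it.

In a functional assay on CNE2Z cells (Homo sapiens) for inhibition, read by MTT assay, with a stated time of 72 h (a higher number here means a weaker inhibitor, a lower number a stronger inhibitor), compound 1 `C=CCc1ccc(OCc2ccc(Cl)cc2Cl)c(-c2ccc(OCc3ccc(Cl)cc3Cl)c(CC=C)c2)c1` gives > 50000 nM, which is a limit of the assay and not a number. Compound 3 `C=CCc1ccc(OCC)c(-c2ccc(OCC)c(CC=C)c2)c1` gives > 50000 nM, also a limit. Compound 1 therefore stands at the limit of > 50000 nM in this assay, at which 2 of the 3 values shown sit. Compound 2 `C=CCc1ccc(OCc2ccc(Cl)cc2Cl)c(-c2ccc(O)c(CC=C)c2)c1` gives a true number, 24200 nM. Among the compounds with values here, the only measured step of this kind is an at least 2.0-fold lower number from compound 1 to compound 2 (0.31 log units; beyond the scatter), and because it starts from a limit, its full size is unknown. Compound 4 `C=CCc1ccc(O)c(-c2ccc(OCc3ccc(Cl)cc3Cl)c(CC=C)c2)c1` makes the same kind of change on the other oxygen: hydrogen in place of 2,4-dichlorobenzyl on an oxygen on an aromatic ring. A similar move toward a lower number in this assay is expected, giving an expected step of an at least 2.5-fold lower number from compound 1 to compound 4 (0.39 log units; beyond the scatter). Compound 4 is estimated at 20000 nM, with an expected range of 8000 nM to 50000 nM.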

Compound 4, half-maximal inhibitory concentration: 11300 nM
Compound 4: middle estimate off by 1.8-fold (0.25 log units), on the high side, and the stated range covers the measured number.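

In this assay, hydrogen in place of 2,4-dichlorobenzyl on this oxygen gives an at least 4.4-fold lower number from compound 1 to compound 4 (0.64 log units; beyond the scatter). The same change on the other oxygen gave an at least 2.0-fold lower number from compound 1 to compound 2 (0.31 log units; beyond the scatter), so in these two steps, removing either 2,4-dichlorobenzyl group moves the number the same way and yields a true value. The full size of both steps stays unknown because they start from a limit: the limit of > 50000 nM in this assay, at which 2 of the 4 values shown sit.

From the compounds shown here alone, whether hydroxy itself matters, or only the loss of 2,4-dichlorobenzyl, stays open. So does the effect of a methyl or an acetic acid chain on this oxygen.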